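Chloro for fluoro on the aryl sulfone of a tricyclic core

The source may report more compounds than this note shows. Statements on the series, on what has been measured and on what is new or still open speak of the compounds shown alone.

Compound 1, `CN1CCC(n2cc(S(=O)(=O)c3ccccc3F)c3cccnc32)C1`: 186 nM
Compound 2, `CN1CCC(n2cc(S(=O)(=O)c3ccccc3Cl)c3cccnc32)C1`: 91 nM
Compound 3, `CCN1CCC(n2cc(S(=O)(=O)c3cccc(F)c3)c3cccnc32)C1`: 132 nM

Of the compounds shown here, three sharing one core have been measured in a functional assay on HeLa cells for antagonist activity at 5-hydroxytryptamine receptor 6 (Homo sapiens), read by cAMP accumulation and immunoassay; a lower number here means a stronger inhibitor, a higher number a weaker inhibitor. Compound 1 `CN1CCC(n2cc(S(=O)(=O)c3ccccc3F)c3cccnc32)C1` gives 186 nM, and compound 2 `CN1CCC(n2cc(S(=O)(=O)c3ccccc3Cl)c3cccnc32)C1` gives 91 nM. Among the compounds with values here, the single change between them is chloro in place of fluoro on an aromatic carbon, and the step it made is a 2.0-fold lower number from compound 1 to compound 2 (0.31 log units; beyond the scatter). Compound 3 `CCN1CCC(n2cc(S(=O)(=O)c3cccc(F)c3)c3cccnc32)C1`, which carries an ethyl rather than a methyl on its saturated ring nitrogen and a fluoro on a different carbon of the aryl sulfone, gives 132 nM in this assay; the difference between the core of compound 3 and the core of compound 1 is not broken down here, and its value and that of compound 1 lie within the scatter of each other.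

Compound 4 `CCN1CCC(n2cc(S(=O)(=O)c3cccc(Cl)c3)c3cccnc32)C1` is not yet measured. It differs from compound 3 by chloro in place of fluoro on an aromatic carbon. This is the same kind of change as that from compound 1 to compound 2, but not the same: there the chloro entered ortho to a large group, here it enters meta to a large group. Within the data shown here, with only one earlier instance of this change, and at a different place on the ring, the expected step from compound 3 to compound 4 in this assay is a 1.8-fold lower number from compound 3 to compound 4 (0.25 log units; within the scatter), a step of roughly the size of a 2.0-fold lower number from compound 1 to compound 2 (0.31 log units; beyond the scatter) but with wide uncertainty. On that basis compound 4 is estimated at 75 nM, expected to fall between 30 nM and 200 nM.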

Compound 4, half-maximal inhibitory concentration: 120 nM
Compound 4: the middle estimate sits 1.6-fold (0.20 log units) below what was measured; the measured number falls inside the stated range.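

In this assay, chloro in place of fluoro on the 3-fluorophenyl group of compound 3 gave a 1.1-fold lower number from compound 3 to compound 4 (0.04 log units; within the scatter), so on this core the change cannot be told apart from no change at all. Set beside the earlier step, the result does not show that the two cores respond differently: the same change on two cores in this assay, a 2.0-fold lower number (0.31 log units; beyond the scatter) from compound 1 to compound 2 and a 1.1-fold lower number (0.04 log units; within the scatter) from compound 3 to compound 4, 1.9-fold (0.27 log units) apart, within the scatter of two such steps. What it does not show is that the change carries over with a fixed size, since there are only two instances, one of them too small to read, and they differ both in where the halogen sits on the ring and in the methyl or ethyl on the saturated ring nitrogen, so neither difference can be separated from the other.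

The compounds shown leave open whether the step from fluoro to chloro depends on the halogen's place on the ring or on the group at the ring nitrogen, a question that both halogen places on a single core would address. They also leave open how a methoxy, a nitrile or a trifluoromethyl would read at the same carbon, and how a longer chain would read on the saturated ring nitrogen.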